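The compounds below may be only part of what the source reports. "The series", "measured", "known", "first", "only" and "open" are said of these compounds alone.

For the measured compounds named here, compound 3 `CCn1cc(C(CC)(CC)c2ccc(C#CC(O)(CC)CC)c(C)c2)cc1C(=O)NCCCN(C)C` stands highest of the three numbers so far in an assay on cells for agonist activity at vitamin D3 receptor (Homo sapiens), read by microscopy (on this read-out higher numbers stand for an effect only at larger amounts of compound and lower numbers for an effect already at smaller amounts), where compound 3 gives 142 nM. Compound 1 `CCN(CC)CCCNC(=O)c1ccc(C(CC)(CC)c2ccc(C#CC(O)(CC)CC)c(C)c2)n1CC` lies nearest, and in this assay compound 1 gives 68.9 nM. Compound 2 `CCn1c(C(=O)N[C@H](C(=O)O)C(C)C)ccc1C(CC)(CC)c1ccc(C#CC(O)(CC)CC)c(C)c1` lies furthest, and in this assay compound 2 gives 17.7 nM. Compound 4 `CCn1cc(C(CC)(CC)c2ccc(C#CC(O)(CC)CC)c(C)c2)cc1C(=O)N[C@H](C(=O)O)C(C)C` has not yet been measured. It differs from compound 3 in one place: 1-carboxy-2-methylpropyl in place of 3-(dimethylamino)propyl on an amide-type nitrogen. Going by the values given here, the only measured step that bears on this change is the one from compound 1 to compound 2, where a carboxy-bearing chain replaced an amine-bearing chain on the amide-type nitrogen and gave a 3.9-fold lower number from compound 1 to compound 2 (0.59 log units; beyond the scatter). Among the compounds with values here, that pair sits on a differently built core, and the leaving group there was 3-(diethylamino)propyl rather than 3-(dimethylamino)propyl, so the transfer is not exact; no other pair in the set speaks to it. Still, a lower number of comparable size is expected, a step of roughly a 3.9-fold lower number from compound 3 to compound 4 (0.60 log units; beyond the scatter). On that basis compound 4 is estimated at 36 nM in this assay, with a range from 12 nM to 110 nM.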

Compound 4, half-maximal effective concentration: 12.7 nM
For compound 4 the middle estimate is 2.8-fold (0.45 log units) above the measured one; the measured number falls inside the stated range.
By their numbers in this assay, from the lowest: compounds 4 and 2 (each within the scatter of the next); then compound 1; then compound 3.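

In this assay the change on the amide-type nitrogen gives an 11-fold lower number from compound 3 to compound 4 (1.05 log units; beyond the scatter) and so lowers the number on a second core, not only on the core of compound 1. Set against a 3.9-fold lower number from compound 1 to compound 2 (0.59 log units; beyond the scatter) the direction is the same in both pairs, and neither goes against it, but the new step is graded large and the earlier one modest, and the two pairs differ in the departing chain as well as in the core, 3-(dimethylamino)propyl in one and 3-(diethylamino)propyl in the other. No measurement in hand accounts for the drop in the number at this nitrogen, on either core.

The compounds shown do not separate the carboxylic acid from the branched isopropyl part of the 1-carboxy-2-methylpropyl chain or from its defined stereocentre, so a methyl ester, an unbranched carboxymethyl chain and the opposite stereocentre would each read on a different part of the change. Going by these compounds, how a primary alcohol in place of the carboxylic acid, or a longer chain carrying the acid, would read at this amide-type nitrogen also stays open.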